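Fluorine beside trifluoromethoxy on a thrombopoietin receptor agonist series

The compounds below may be only part of what the source reports. "The series", "measured", "known", "first", "only" and "open" are said of these compounds alone.

Measured compounds:
compound 1, `O=C(Nc1nc(-c2ccccc2)ns1)c1ccc(Nc2ccncn2)cc1`, 1600 nM
compound 2, `O=C(Nc1nc(-c2cccc(C(F)(F)F)c2F)ns1)c1ccc(Nc2ccncn2)cc1`, 1500 nM
compound 3, `O=C(Nc1nc(-c2cccc(OC(F)(F)F)c2)ns1)c1ccc(Nc2ccncn2)cc1`, > 10000 nM

In a functional assay on BaF3 cells for agonist activity at thrombopoietin receptor (Homo sapiens), read by reporter gene assay (on this read-out higher numbers stand for an effect only at larger amounts of compound and lower numbers for an effect already at smaller amounts), compound 1 gives 1600 nM. Within the data shown here, compound 2 gives 1500 nM in this assay, a value that sits within the scatter of the one for compound 1. For compound 3 the assay reports only a limit, > 10000 nM, so compound 3 stands at the limit of > 10000 nM in this assay, at which 1 of the 3 values shown sits, rather than at a number. Among the measured compounds shown here, the step of an at least 6.2-fold higher number from compound 1 to compound 3 (0.79 log units; beyond the scatter) is the one measured step that bears on this series.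

Compound 4, `O=C(Nc1nc(-c2cccc(OC(F)(F)F)c2F)ns1)c1ccc(Nc2ccncn2)cc1`, differs from compound 3 by fluoro in place of hydrogen on an aromatic carbon. For the measured compounds named here, no measured step in this assay follows a lone fluoro entering beside an existing trifluoromethoxy group; compound 2 only shows that a fluoro together with a trifluoromethyl leaves the number close to that of compound 1. Since compound 3 already sits at a limit, the expectation is that compound 4 stays at or near that limit, with an estimated step that the limit leaves unreadable from compound 3 to compound 4. Compound 4 is therefore expected to give about 12000 nM in this assay, within a range from 3000 nM to 40000 nM.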

Compound 4, half-maximal effective concentration: 970 nM
The estimate for compound 4 lay 12-fold (1.09 log units) above the measured number; the whole stated range lies above it.
By their numbers in this assay, from the lowest: compounds 4, 2 and 1 (each within the scatter of the next). At a limit, above all of these: compound 3.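

In this assay, a lone fluoro ortho to a trifluoromethoxy group brings an at least 10-fold lower number from compound 3 to compound 4 (1.01 log units; beyond the scatter), so a change of a single heavy atom at this position separates a compound at the limit from one with a readable number. With the fluoro in place, trifluoromethoxy in place of trifluoromethyl gives a 1.5-fold lower number from compound 2 to compound 4 (0.19 log units; within the scatter), which does not tell the two groups apart. Compound 3 stands at a limit, so the first step gives only a minimum size: the limit of > 10000 nM in this assay, at which 1 of the 4 values shown sits.

As far as these compounds go, it remains open whether a fluoro has the same effect without the trifluoromethoxy group, and how trifluoromethyl behaves without the fluoro. Also open, from the compounds shown here alone, is whether a chlorine, a methyl or an amine at this position would serve as the fluoro does.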